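Cyclopentyl to cyclohexyl: one more step in ring size

The compounds below may be only part of what the source reports. "The series", "measured", "known", "first", "only" and "open" are said of these compounds alone.

Measured in a functional assay (Nicotiana tabacum); a higher number here means a weaker inhibitor, a lower number a stronger inhibitor:
- compound 1 `CSc1nc(NC2CC2)c2cccnc2n1` (4900 nM)
- compound 2 `CSc1nc(NC2CCCC2)c2cccnc2n1` (490 nM)

Of these two, compound 2 has the lower number (490 nM) and is the stronger inhibitor, while compound 1 sits clearly higher (4900 nM). The next compound to consider is compound 3 `CSc1nc(NC2CCCCC2)c2cccnc2n1`, which keeps the shared core and alters one group (cyclohexyl in place of cyclopentyl on a nitrogen on an aromatic ring). Put simply, this is cyclohexyl in place of cyclopentyl on a nitrogen on an aromatic ring.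

For the measured compounds named here, only one measured step bears on this site: cyclopentyl in place of cyclopropyl (a 10-fold lower number from compound 1 to compound 2 (1.00 log units; beyond the scatter)). That step lies beyond the scatter and favoured the larger ring, but a single step is thin evidence for a trend, and nothing yet shows how a six-membered ring behaves here. The new change enlarges the ring less than that step did, so a much smaller move in the same direction seems a reasonable expectation, possibly one lost in the scatter. The expected step is small (a 1.6-fold lower number from compound 2 to compound 3 (0.21 log units; within the scatter)). The estimate for compound 3 is 300 nM (expected range 100 nM to 900 nM).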

Compound 3, half-maximal inhibitory concentration: 5650 nM
For compound 3 the middle estimate is 19-fold (1.27 log units) below the measured one; measured number outside the range, above it.
By their numbers in this assay, from the lowest: compound 2; then compounds 1 and 3 (each within the scatter of the next).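

In this assay, the ring on this nitrogen does not follow a simple rule that larger is better. The cyclohexyl change brings a 12-fold higher number from compound 2 to compound 3 (1.06 log units; beyond the scatter) and so runs against the earlier 10-fold lower number from compound 1 to compound 2 (1.00 log units; beyond the scatter) from the smaller ring to the larger one. The smallest and largest of the three rings end up level, with a 1.2-fold higher number from compound 1 to compound 3 (0.06 log units; within the scatter) as the comparison, so among these compounds only the cyclopentyl ring of compound 2 stands apart. At this position, then, a change from a five-membered to a six-membered ring can matter a great deal, even though it looks like a small edit on paper. Nothing measured here explains why the cyclohexyl compound reads so differently from the cyclopentyl one.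

The compounds shown leave open how narrow this preference is, since cyclobutyl and cycloheptyl would fill in the ring sizes on either side, and an open chain such as pentyl would show whether a ring is needed at all. They also leave open whether a hydroxyl group on the cyclohexyl ring, or a tetrahydropyranyl ring in its place, would behave like cyclohexyl or move the number back towards that of compound 2.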